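Swapping 3,4-Difluorophenyl for 4-Bromophenyl in Compound 3

A few compounds are considered here, and "the series" means these few. Any claim that something is new, unique, unknown or untested is made for them only; others in the source may bear on it.

Among the compounds with values here, in an ADME assay on HUVEC cells (Homo sapiens) for inhibition, read by MTT assay, with a stated time of 48 h (on this read-out lower numbers stand for stronger inhibition and higher numbers for weaker inhibition), compound 2 (`Fc1ccc(/C=N/Nc2nc(-c3ccc(F)c(F)c3)cs2)cc1F`) gives 59700 nM as the only actual number so far. In this assay compound 1 (`COc1cc(/C=N/Nc2nc(-c3ccc(Br)cc3)cs2)cc(Br)c1OC`), which carries 4-bromophenyl, reads > 100000 nM and that is a limit of the assay, not a number. Within the data shown here, compound 2 therefore stands alone on the scale, with a single limit as its only company, and no step between two measured compounds is available to serve as a guide.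

Compound 3 (`Fc1ccc(/C=N/Nc2nc(-c3ccc(Br)cc3)cs2)cc1F`) has not yet been measured. It differs from compound 2 in one place: 4-bromophenyl in place of 3,4-difluorophenyl on an aromatic carbon and the change puts 4-bromophenyl in place of 3,4-difluorophenyl on an aromatic carbon. Starting from compound 2 at 59700 nM and with 4-bromophenyl also present in compound 1, only a small move toward weaker inhibition is expected in this assay here. The estimated change is a 1.4-fold higher number from compound 2 to compound 3 (0.15 log units; within the scatter) and it may not exceed the usual scatter. The estimated value for compound 3 is 85000 nM with 40000 nM to 170000 nM as its expected range.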

Compound 3, half-maximal inhibitory concentration: > 100000 nM
Compound 3: no number, only a limit (the forecaster's own chance of this, stated with the estimate: 40%); at least 1.1-fold (0.07 log units) between middle value and limit.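

This is the first comparison shown between two compounds that differ in one place, on an aromatic carbon of the five-membered aromatic ring with 1 nitrogen and 1 sulfur: in this assay, 4-bromophenyl in place of 3,4-difluorophenyl gives an at least 1.6-fold higher number from compound 2 to compound 3 (0.22 log units; that floor lies within the scatter). That floor lies within the scatter, so the change cannot yet be called a real loss of inhibition, although it shows no sign of a gain either. The true size of the step stays unknown because the read-out for compound 3 is a limit of the assay and not a number: the limit of > 100000 nM in this assay, at which 2 of the 3 values shown sit.

Among the groups shown at this place, only 3,4-difluorophenyl gives an actual number, so the compounds leave open how much the read-out depends on what this ring carries. On these data alone, whether a phenyl ring bearing an amine or a carboxylic acid at this place would give a number under the limit, and so allow a step of known size, also remains open.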